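Trading 4-pentylphenyl for butyl in compound 3

The source may hold more compounds than are shown below. What is called first, only, known or untested is meant among the compounds shown, and "the series" means these compounds.

Compound 1 `CCCCCCCCC#Cc1cn(C/C=C\CN2C(=O)c3ccccc3C2=O)c(=O)[nH]c1=O`: 39000 nM
Compound 2 `CCCCCc1ccc(C#Cc2cn(C/C=C\CN3C(=O)c4ccccc4C3=O)c(=O)[nH]c2=O)cc1`: 18000 nM
Compound 3 `CCCCCc1ccc(C#Cc2cn(C/C=C/CN3C(=O)c4ccccc4C3=O)c(=O)[nH]c2=O)cc1`: 4300 nM

In a functional assay on HepG2 cells (Homo sapiens) for antiproliferative activity, read by MTT assay, with a stated time of 3 days (on this read-out lower numbers stand for stronger inhibition and higher numbers for weaker inhibition), compound 3 gives the lowest of the three numbers, at 4300 nM. Compound 4 `CCCCC#Cc1cn(C/C=C/CN2C(=O)c3ccccc3C2=O)c(=O)[nH]c1=O`, not yet measured, keeps the double bond of compound 3 and carries butyl in place of 4-pentylphenyl on a triple-bonded carbon. The step that bears on this is a similar exchange, octyl to 4-pentylphenyl, seen as a 2.2-fold lower number from compound 1 to compound 2 (0.34 log units; beyond the scatter). The other step, a 4.2-fold lower number from compound 2 to compound 3 (0.62 log units; beyond the scatter), concerns only the double bond, so it offers no guide here. Run in reverse, the first step suggests that losing the 4-pentylphenyl should raise the number modestly, though butyl is not octyl. The expected change is a 2.3-fold higher number from compound 3 to compound 4 (0.37 log units; beyond the scatter). For compound 4 the estimated value is 10000 nM, with an expected range of 3500 nM to 30000 nM.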

Compound 4, half-maximal inhibitory concentration: 7900 nM
Compound 4: the middle estimate sits 1.3-fold (0.10 log units) above what was measured; the range from low to high includes it.
By their numbers in this assay, from the lowest: compounds 3 and 4 (each within the scatter of the next); then compound 2; then compound 1.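

With the double bond drawn E, a 1.8-fold higher number from compound 3 to compound 4 (0.26 log units; within the scatter) in this assay shows that on the triple-bonded carbon, butyl, which has no ring, cannot be told apart from 4-pentylphenyl. The earlier 2.2-fold lower number from compound 1 to compound 2 (0.34 log units; beyond the scatter) with the double bond drawn Z had favoured 4-pentylphenyl over octyl, but an aromatic ring at this position is evidently not needed with the E double bond. Nothing at hand explains this step. The compounds shown leave open how a longer chain such as octyl would read with the E double bond, and whether butyl keeps this standing with the Z double bond. They also leave open what an amine or a hydroxyl at the end of the butyl chain would do.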